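This account rests on a few compounds, and the source may have more. Where it says the series, first, only, none or still open, it means among the compounds named here.

In a functional assay on MGC-803 cells (Homo sapiens) for antiproliferative activity, read by CellTiter-Glo, with a stated time of 72 h (on this read-out higher numbers stand for weaker inhibition and lower numbers for stronger inhibition), compound 3 `O=C(NO)c1ccc(/C=C/c2ccnc(-c3ccc(F)cc3)c2)cc1` reads > 10000 nM. This is a limit and not a number: the limit of > 10000 nM in this assay, at which 1 of the 3 values shown sits. The other two measured compounds give numbers: compound 1 `O=C(NO)c1ccc(/C=C/c2ccnc(-c3ccccc3O)c2)cc1` gives 1420 nM and compound 2 `O=C(NO)c1ccc(/C=C/c2ccnc(-c3cccc(CO)c3)c2)cc1` gives 1740 nM. These two values lie within the scatter of each other, with a 1.2-fold higher number from compound 1 to compound 2 (0.09 log units; within the scatter).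

Compound 4 `Cc1ccc(-c2cc(/C=C/c3ccc(C(=O)NO)cc3)ccn2)cc1` comes from compound 3 by one change, methyl in place of fluoro on an aromatic carbon, para to a large group.

For the measured compounds named here, no measured step exchanges these two groups, so the evidence is indirect. The nearest steps replace the whole aryl group, with an at least 7.0-fold higher number from compound 1 to compound 3 (0.84 log units; beyond the scatter) and an at least 5.7-fold higher number from compound 2 to compound 3 (0.75 log units; beyond the scatter). Both lie beyond the scatter, and both are lower bounds on size. Neither 4-fluorophenyl nor 4-methylphenyl carries the hydroxy group of 2-hydroxyphenyl or 3-(hydroxymethyl)phenyl, so compound 4 is expected to stay closer to compound 3 than to compound 1 or compound 2.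

The expected result is no step beyond the scatter in this assay, and the estimated step is a number no higher from compound 3 to compound 4 (the limit leaves the size open). For compound 4 the estimate is 10000 nM, with an expected range from 3000 nM to 30000 nM.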

Compound 4, half-maximal inhibitory concentration: 1910 nM
Beside the measured number, compound 4's estimate is 5.2-fold (0.72 log units) above it, outside the stated range (below it).
By their numbers in this assay, from the lowest: compounds 1, 2 and 4 (each within the scatter of the next). At a limit, above all of these: compound 3.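

In this assay, methyl in place of fluoro, para to a large group, gives an at least 5.2-fold lower number from compound 3 to compound 4 (0.71 log units; beyond the scatter), so this position responds to the exchange of a single heavy atom, and a hydroxy group on the aryl ring is not required for a measurable value. The 4-methylphenyl group carries no hydroxy group, yet exchanging the hydroxy-bearing aryl groups for it stays within the scatter, with a 1.1-fold higher number from compound 2 to compound 4 (0.04 log units; within the scatter) and a 1.3-fold higher number from compound 1 to compound 4 (0.13 log units; within the scatter); the earlier contrast with 4-fluorophenyl therefore does not separate aryl groups with and without a hydroxy group. Compound 3 stands at a limit and not at a number, so the step to it is bounded on one side only: the limit of > 10000 nM in this assay, at which 1 of the 4 values shown sits.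

The compounds shown leave open whether the difference comes from the presence of fluoro, which would hold for other groups in this place, or from something specific to methyl. A plain phenyl, a 4-chlorophenyl or a 4-methoxyphenyl on the same core would help tell these two readings apart.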